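Trifluoromethyl in place of tert-butyl on an aromatic carbon

The source may report more compounds than this note shows. Statements on the series, on what has been measured and on what is new or still open speak of the compounds shown alone.

compound 1 `CCC(=O)c1ccccc1OC(=O)c1coc(-c2ccccc2)n1` - 1.8%
compound 2 `CCC(C)c1ccccc1OC(=O)c1coc(-c2ccccc2)n1` - 0.2%
compound 3 `CC(C)(C)c1ccccc1OC(=O)c1coc(-c2ccccc2)n1` - 0.7%

In a physicochemical assay for metabolic stability, read by LC-MS, in simulated gastric fluid, with a stated time of 15 min, tested at 50 uM (on this read-out lower numbers stand for a less stable compound and higher numbers for a more stable compound), compound 3 gives 0.7%, which lies within the scatter of both other compounds. Compound 4 `O=C(Oc1ccccc1C(F)(F)F)c1coc(-c2ccccc2)n1` keeps the shared core but carries trifluoromethyl in place of tert-butyl on an aromatic carbon. For the measured compounds named here, no compound with trifluoromethyl has been measured yet, so the closest guide is the three swaps already seen on this carbon: a number 1.6 percentage points lower from compound 1 to compound 2 (within the scatter), a number 1.1 percentage points lower from compound 1 to compound 3 (within the scatter) and a number 0.5 percentage points higher from compound 2 to compound 3 (within the scatter). All three were small. No step beyond the scatter is therefore expected in this assay, and the estimated change is a number 0.1 percentage points higher from compound 3 to compound 4 (within the scatter). The expected value for compound 4 is 0.8%, with an estimated range of 0% to 4%.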

Compound 4, percent of the compound remaining: 1.2%
For compound 4 the middle estimate is 0.4 percentage points below the measured one; measured number inside the range.
By their numbers in this assay, from the lowest: compounds 2, 3, 4 and 1 (each within the scatter of the next).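

In this assay, for the compounds shown here, trifluoromethyl brings fluorine to this aromatic carbon for the first time, yet the swap for tert-butyl gives a number 0.5 percentage points higher from compound 3 to compound 4 (within the scatter) and the swap for sec-butyl gives a number 1 percentage points higher from compound 2 to compound 4 (within the scatter) while the swap for propanoyl gives a number 0.6 percentage points lower from compound 1 to compound 4 (within the scatter) and so all four groups now lie within the scatter of one another. No supporting measurement explains this result. From the compounds shown here alone, whether an amine or a carboxylic acid on this carbon would move the number beyond the scatter remains open, as does the effect of changes elsewhere on the shared core.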